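The compounds below may be only part of what the source reports. "The series", "measured", "known", "first", "only" and "open" are said of these compounds alone.

In a functional assay on V79-379A cells (Cricetulus griseus) for cytotoxicity, read by MTT assay, in the presence of a further agent that is not named here (a higher number here means a weaker inhibitor, a lower number a stronger inhibitor), compound 1 `COC1=CC(=O)c2c(c(COC(=O)c3ccccc3)cn2C)C1=O` gives 40 nM, compound 2 `COC1=CC(=O)c2c(c(COC(=O)c3ccccc3)c(C)n2C)C1=O` gives 200 nM and compound 3 `COC1=CC(=O)c2c(c(COc3ccccc3)c(C)n2C)C1=O` gives 700 nM, the highest number of the three. Compound 4 `COC1=CC(=O)c2c(c(Cc3ccc(O)c(F)c3)c(C)n2C)C1=O` carries 3-fluoro-4-hydroxyphenyl in place of phenoxy on a saturated chain carbon bound to an aromatic carbon. The nearest evidence is the modest 3.5-fold higher number from compound 2 to compound 3 (0.54 log units; beyond the scatter), a change on the oxygen attached to that same carbon. The modest 5.0-fold higher number from compound 1 to compound 2 (0.70 log units; beyond the scatter) lies elsewhere on the core. Among the measured compounds shown here, no measured compound lacks that oxygen, so the forecast is loose. A further modest rise is expected, with the estimated step being a 2.9-fold higher number from compound 3 to compound 4 (0.46 log units; beyond the scatter). Compound 4 is estimated at 2000 nM, with an expected range of 500 nM to 10000 nM.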

Compound 4, half-maximal inhibitory concentration: 280000 nM
The estimate for compound 4 lay 140-fold (2.15 log units) below the measured number, outside the stated range (above it).
By their numbers in this assay, from the lowest: compound 1; then compound 2; then compound 3; then compound 4.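

In this assay, among the compounds shown here, the swap of phenoxy for 3-fluoro-4-hydroxyphenyl on the saturated chain carbon gives a 400-fold higher number from compound 3 to compound 4 (2.60 log units; beyond the scatter), the only large step, so the group on this carbon can shift the number far more than the earlier changes did. The swap removes the oxygen on that carbon and brings in a fluorine and a hydroxyl at once, so this single step cannot separate their contributions. Nothing measured here explains the size of the step. From the compounds shown here alone, it remains open whether the plain benzyl group, without fluorine or hydroxyl, would behave like compound 4, and how an amine at this carbon would compare.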